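The source may hold more compounds than are shown below. What is called first, only, known or untested is meant among the compounds shown, and "the series" means these compounds.

In an ADME assay on HEK293 cells (Homo sapiens) for cytotoxicity, read by MTT assay, with a stated time of 72 h (a lower number here means a stronger inhibitor, a higher number a weaker inhibitor), compound 1 `O=C(CN1CCN(C(=O)c2ccc(Cl)cc2)CC1)N1CCN(CCCc2c[nH]c3ccc(F)cc23)CC1` gives 44500 nM, and compound 2 `O=C(CN1CCN(C(=O)c2ccc(F)cc2)CC1)N1CCN(CCCc2c[nH]c3ccc(F)cc23)CC1` gives 102000 nM, the higher of the two numbers. Compound 3 `O=C(CN1CCN(C(=O)c2cccc(Cl)c2)CC1)N1CCN(CCCc2c[nH]c3ccc(F)cc23)CC1` differs from compound 2 by 3-chlorophenyl in place of 4-fluorophenyl on a carbonyl carbon. Going by the values given here, only one measured step bears on this change: fluoro in place of chloro on an aromatic carbon, a 2.3-fold higher number from compound 1 to compound 2 (0.36 log units; beyond the scatter), modest but beyond the scatter. Read in reverse, it suggests a similarly modest drop, although the chloro of compound 3 does not match that of compound 1. The expected change in this assay is a 1.9-fold lower number from compound 2 to compound 3 (0.27 log units; within the scatter). The estimate for compound 3 is 55000 nM, with an expected range of 27000 nM to 105000 nM.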

Compound 3, half-maximal inhibitory concentration: 66200 nM
Compound 3: middle estimate off by 1.2-fold (0.08 log units), on the low side; the range from low to high includes it.
By their numbers in this assay, from the lowest: compounds 1, 3 and 2 (each within the scatter of the next, the first and the last beyond it).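

In this assay, the step to 3-chlorophenyl on the carbonyl carbon gives a 1.5-fold lower number from compound 2 to compound 3 (0.19 log units; within the scatter) when it replaces 4-fluorophenyl, and a 1.5-fold higher number from compound 1 to compound 3 (0.17 log units; within the scatter) when it replaces 4-chlorophenyl. Compound 3 thus lies within the scatter of both compound 1 and compound 2, though those two lie beyond it from each other, so this change does not separate it from either. Nothing measured here accounts for these numbers.

The compounds shown leave open whether unsubstituted phenyl, or a phenyl carrying a methoxy group, an amine or a carboxylic acid, would move the number further at this place.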